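Replacing the aryl group with a phenoxy group

The source may hold more compounds than are shown below. What is called first, only, known or untested is meant among the compounds shown, and "the series" means these compounds.

Of the compounds shown here, three sharing one core have been measured in an ADME assay on HepG2 cells (Homo sapiens) for cytotoxicity, read by luminescence, CellTiter-Glo and ATP content, with a stated time of 72 h; a lower number here means that less compound is needed, a higher number that more compound is needed for the effect. Compound 1 `COc1ccc(F)cc1CNCCCNc1ccnc2cc(Oc3cccc(N(C)C)c3)ccc12` gives 3300 nM, compound 2 `COc1ccc(F)cc1CNCCCNc1ccnc2cc(Cc3cccc(C(F)(F)F)c3)ccc12` gives 440 nM, and compound 3 `COc1ccc(F)cc1CNCCCNc1ccnc2cc(-c3ccc(C(C)(C)C)cc3)ccc12` gives 620 nM. Compound 3 thus holds the second highest of the three numbers, though the step of a 1.4-fold higher number from compound 2 to compound 3 (0.15 log units; within the scatter) is within the scatter, while the step of a 5.3-fold lower number from compound 1 to compound 3 (0.73 log units; beyond the scatter) lies beyond it. Compound 4 `COc1ccc(F)cc1CNCCCNc1ccnc2cc(Oc3ccccc3OC)ccc12` differs from compound 3 in one place: 2-methoxyphenoxy in place of 4-(tert-butyl)phenyl on an aromatic carbon. For the measured compounds named here, the step that bears most directly on this change is a 5.3-fold lower number from compound 1 to compound 3 (0.73 log units; beyond the scatter), in which a phenoxy group gave way to a directly bound phenyl and the number fell; compound 4 brings a phenoxy group back, though with a different substituent, so no exact precedent exists. The step of a 7.5-fold lower number from compound 1 to compound 2 (0.88 log units; beyond the scatter) points the same way. The number for compound 4 is therefore expected to rise in this assay, by an estimated step of a 2.9-fold higher number from compound 3 to compound 4 (0.46 log units; beyond the scatter). Compound 4 is estimated at 1800 nM, within a range from 600 nM to 5000 nM.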

Compound 4, half-maximal effective concentration: 6400 nM
Compound 4: middle estimate off by 3.6-fold (0.55 log units), on the low side, outside the stated range (above it).
By their numbers in this assay, from the lowest: compounds 2 and 3 (each within the scatter of the next); then compounds 1 and 4 (each within the scatter of the next).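

At this position of the shared core, the change to 2-methoxyphenoxy in this assay gives a 10-fold higher number from compound 3 to compound 4 (1.01 log units; beyond the scatter), and the comparison with the benzyl-linked group gives a 15-fold higher number from compound 2 to compound 4 (1.16 log units; beyond the scatter), both large steps. Between the two phenoxy compounds, the result is a 1.9-fold higher number from compound 1 to compound 4 (0.29 log units; within the scatter), so replacing 3-(dimethylamino)phenyl with 2-methoxyphenyl on the oxygen leaves the number within the scatter, and among these four compounds, both oxygen-linked groups give higher numbers than the two groups without that oxygen, with no compound going against this. Nothing measured here explains the split.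

On these data alone, each large step changes both the link and the substituents on the outer ring, so the share of the oxygen alone remains open. An amine or a sulfur atom in place of that oxygen, carrying the same 2-methoxyphenyl, would separate the two.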